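The compounds below may be only part of what the source reports. "The series", "measured", "known", "first", "only" and "open" are said of these compounds alone.

Series notes. Compound 3 `O=C(Nc1ccc(Cl)cc1)Nc1cccc(NC(=O)c2ccccn2)c1` gives 3620 nM in a functional assay on A549 cells (Homo sapiens) for antiproliferative activity, read by MTT assay, with a stated time of 48 h; on this read-out lower numbers stand for stronger inhibition and higher numbers for weaker inhibition; it stands second highest of the three numbers, within the scatter of compound 2 `O=C(Nc1cccc(Cl)c1)Nc1cccc(NC(=O)c2ccccn2)c1` at 2850 nM and of compound 1 `O=C(Nc1ccccc1)Nc1cccc(NC(=O)c2ccccn2)c1` at 5190 nM. Compound 4 `O=C(Nc1ccc([N+](=O)[O-])cc1)Nc1cccc(NC(=O)c2ccccn2)c1` differs from compound 3 by nitro in place of chloro on an aromatic carbon. Among the compounds with values here, no measured step exchanges chloro for nitro; the nearest guidance comes from the same ring, where a 1.4-fold lower number from compound 1 to compound 3 (0.16 log units; within the scatter) and a 1.3-fold higher number from compound 2 to compound 3 (0.10 log units; within the scatter) both stayed within the scatter, as did a 1.8-fold lower number from compound 1 to compound 2 (0.26 log units; within the scatter). On that basis no step beyond the scatter is expected in this assay for compound 4, which amounts to an expected 1.0-fold lower number from compound 3 to compound 4 (0.00 log units; within the scatter). Compound 4 is therefore estimated at 3600 nM, with a range of 1500 nM to 9000 nM.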

Compound 4, half-maximal inhibitory concentration: 320 nM
Compound 4: the middle estimate sits 11-fold (1.05 log units) above what was measured, and the stated range ends above it.
By their numbers in this assay, from the lowest: compound 4; then compounds 2, 3 and 1 (each within the scatter of the next).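

In this assay, within the data shown here, nitro is the first group on this ring to carry the number beyond the scatter, with an 11-fold lower number from compound 3 to compound 4 (1.05 log units; beyond the scatter) and a 16-fold lower number from compound 1 to compound 4 (1.21 log units; beyond the scatter) and also an 8.9-fold lower number from compound 2 to compound 4 (0.95 log units; beyond the scatter) as the steps. Chloro at the same place, para to a large group, stayed within the scatter of hydrogen, so this position is not indifferent to what it carries, and the outcome depends on the group rather than on replacing hydrogen alone. Nothing available here accounts for the difference between nitro and chloro.

Open, from the compounds shown here alone, is whether an amine or a carboxylic acid at this place would keep the lower number. Also open, going by these compounds, is whether nitro elsewhere on the ring would do the same.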